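The source may hold more compounds than are shown below. What is called first, only, known or untested is meant among the compounds shown, and "the series" means these compounds.

Going by the values given here, compound 2 `COc1cc(-c2nc(-c3cnccn3)no2)ccc1O` is one of two compounds measured in a functional assay on the whole organism (strain Charles Foster albino) for inhibition, with Rattus norvegicus as the target, read by paw edema, with stated times of 30 min and 3 h, at a dose of 50 mg/kg by the oral route; on this read-out higher numbers stand for more inhibition at the one dose given (going by the name of the read-out) and lower numbers for less inhibition. In this assay compound 2 gives 26%, and compound 1 `COc1cc(-c2nc(-c3ccccn3)no2)ccc1O` gives 24%, so the two numbers sit within the scatter of each other: a number 2 percentage points higher from compound 1 to compound 2 (within the scatter).

Compound 3 `COc1cc(-c2nc(-c3ccncc3)no2)ccc1O` has not yet been measured. It differs from compound 2 in one place: pyridin-4-yl in place of pyrazin-2-yl on an aromatic carbon.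

Among the compounds with values here, the only measured step that bears on this change is the one from compound 1 to compound 2, which also exchanged one six-membered aromatic ring for another on the same aromatic carbon of the shared core, and it stayed within the scatter. On that basis a step of no more than the scatter is expected in this assay, with no preferred direction, so that for compound 3 a value of 25% is estimated, between 12% and 38%. The expected step is a number 1 percentage points lower from compound 2 to compound 3 (within the scatter).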

Compound 3, a percentage reported as inhibition, in the whole organism at one dose (the size of the read-out at that dose, not a potency): 14%
Compound 3: middle estimate off by 11 percentage points, on the high side; measured number inside the range.
By their numbers in this assay, from the lowest: compounds 3, 1 and 2 (each within the scatter of the next, the first and the last beyond it).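

This position is not indifferent to which six-membered aromatic ring it carries: pyridin-4-yl in place of pyrazin-2-yl gives a number 12 percentage points lower from compound 2 to compound 3 (beyond the scatter) in this assay, the only step among these compounds to pass beyond the scatter. Pyridin-4-yl in place of pyridin-2-yl gives a number 10 percentage points lower from compound 1 to compound 3 (within the scatter) and so stays just inside the scatter, which means compound 1 cannot be separated from either of the other two, and the clear difference rests on a single pair. Nothing available explains why this ring exchange separates compound 2 from compound 3.

From the compounds shown here alone, it remains open how this carbon would respond to pyridin-3-yl, to an amine or to a carboxylic acid in place of these rings. Going by these compounds, it is also open whether the same difference would hold with another dose or with changes elsewhere on the shared core.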